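The source may report more compounds than this note shows. Statements on the series, on what has been measured and on what is new or still open speak of the compounds shown alone.

For the measured compounds named here, in a functional assay on A549 cells (Homo sapiens) for inhibition, read by MTT assay, with a stated time of 24 h (a lower number here means a stronger inhibitor, a higher number a weaker inhibitor), compound 1 `CC1(C)[C@H]2CC[C@]1(C)N(Cc1cn(-c3ccccc3F)nn1)C(=O)C2` gives 240 nM, the highest of the three numbers measured so far. Compound 2 `CC1(C)[C@H]2CC[C@]1(C)N(Cc1cn(-c3ccc(O)cc3)nn1)C(=O)C2` gives 140 nM and compound 3 `Cc1ccccc1-n1cc(CN2C(=O)C[C@@H]3CC[C@@]2(C)C3(C)C)nn1` gives 90 nM. The step of a 1.7-fold lower number from compound 1 to compound 2 (0.23 log units; within the scatter) lies within the scatter, whereas a 2.7-fold lower number from compound 1 to compound 3 (0.43 log units; beyond the scatter) is modest; the step of a 1.6-fold lower number from compound 2 to compound 3 (0.19 log units; within the scatter) is again within the scatter. Compound 4 `COc1ccc(-n2cc(CN3C(=O)C[C@@H]4CC[C@@]3(C)C4(C)C)nn2)cc1` differs from compound 1 by 4-methoxyphenyl in place of 2-fluorophenyl on an aromatic nitrogen. Going by the values given here, the closest precedent is the exchange of the 2-fluorophenyl for another substituted phenyl on the aromatic nitrogen, as in a 1.7-fold lower number from compound 1 to compound 2 (0.23 log units; within the scatter), which gave only a small movement to a lower number. Compound 4 is therefore expected at 150 nM, in the range 70 nM to 320 nM, an expected step of a 1.6-fold lower number from compound 1 to compound 4 (0.20 log units; within the scatter), toward a lower number but likely within the scatter.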

Compound 4, half-maximal inhibitory concentration: 50 nM
Compound 4: middle estimate off by 3.0-fold (0.48 log units), on the high side; measured number below the stated range.
By their numbers in this assay, from the lowest: compounds 4, 3, 2 and 1 (each within the scatter of the next, the first and the last beyond it).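

In this assay, for the compounds shown here, methyl in place of hydrogen on the oxygen gives a 2.8-fold lower number from compound 2 to compound 4 (0.45 log units; beyond the scatter) and so separates two groups that both carry oxygen on the phenyl ring, which the earlier compounds could not show. With 4-methoxyphenyl on the aromatic nitrogen, a 4.8-fold lower number from compound 1 to compound 4 (0.68 log units; beyond the scatter) is the largest step in the series, while a 1.8-fold lower number from compound 3 to compound 4 (0.26 log units; within the scatter) does not separate 4-methoxyphenyl from 2-methylphenyl. Nothing available explains these steps. Still open, on these data alone, is how an amine or a carboxylic acid in place of the methoxy group would read, and whether a longer chain on the oxygen would hold the number.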